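The source may hold more compounds than are shown below. What is called first, only, known or untested is meant among the compounds shown, and "the series" means these compounds.

Compound 1, `Cc1ccc(Cl)cc1COc1ccccc1C(=O)Nc1cccnc1`: 1100 nM
Compound 2, `COc1ccc(OC)c(COc2ccccc2C(=O)Nc2cccnc2)c1`: 2800 nM
Compound 3, `COc1ccc(Cl)cc1COc1ccccc1C(=O)Nc1cccnc1`: 670 nM

In an assay on lysate for inhibition of phosphatidylcholine:ceramide cholinephosphotransferase 2 (Homo sapiens), read by HPLC, with stated times of 30 min and 2 h (a higher number here means a weaker inhibitor, a lower number a stronger inhibitor), compound 3 holds the lowest of the three numbers. One step is a 1.6-fold lower number from compound 1 to compound 3 (0.22 log units; within the scatter), within the scatter, whereas the other step is a 4.2-fold lower number from compound 2 to compound 3 (0.62 log units; beyond the scatter). Compound 4, `CCCCCCOc1ccc(Cl)cc1COc1ccccc1C(=O)Nc1cccnc1`, is not yet measured. It differs from compound 3 by pentyl in place of hydrogen on a saturated chain carbon bound to an oxygen on an aromatic ring; read one bond further out, methoxy becomes hexyloxy. Neither measured step bears directly on this change: one swaps methyl for methoxy and the other methoxy for chloro, and neither extends a chain. With nothing pointing in either direction, compound 4 is expected to stay close to compound 3, with a step of a 1.0-fold higher number from compound 3 to compound 4 (0.02 log units; within the scatter), and its estimated value is 700 nM, within 200 nM to 2500 nM.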

Compound 4, half-maximal inhibitory concentration: 520 nM
For compound 4 the middle estimate is 1.3-fold (0.13 log units) above the measured one, and the stated range covers the measured number.
By their numbers in this assay, from the lowest: compounds 4, 3 and 1 (each within the scatter of the next, the first and the last beyond it); then compound 2.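

In this assay, pentyl can be added on the saturated chain carbon bound to an oxygen on an aromatic ring without moving the number beyond the scatter (a 1.3-fold lower number from compound 3 to compound 4 (0.11 log units; within the scatter)). Measured against methyl, hexyloxy gives a step beyond the scatter (a 2.1-fold lower number from compound 1 to compound 4 (0.33 log units; beyond the scatter)), whereas the step from methyl to methoxy stayed within it. No evidence is available to explain these numbers. From the compounds shown here alone, whether a longer chain would still hold the number remains open, as does the effect of an amine or a carboxylic acid at the end of the chain.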